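A few compounds are considered here, and "the series" means these few. Any claim that something is new, unique, unknown or untested is made for them only; others in the source may bear on it.

Three compounds share one core and differ only in the aryl group fixed on a double-bonded chain carbon bound to a double-bonded chain carbon. Compound 1 `COc1ccc(C(=O)/C=C/c2cccc(Cl)c2)c2c1C=CC(C)(C)O2` carries a 3-chlorophenyl there, and in a functional assay on HCT-116 cells (Homo sapiens) for antiproliferative activity, read by MTT assay, with a stated time of 24 h (a lower number here means a stronger inhibitor, a higher number a weaker inhibitor), compound 1 gives only a limit, > 10000 nM. Compound 2 `COc1ccc(C(=O)/C=C/c2cccs2)c2c1C=CC(C)(C)O2` carries a thiophen-2-yl, and in this assay compound 2 likewise reaches only a limit, > 10000 nM. Compound 3 `COc1ccccc1/C=C/C(=O)c1ccc(OC)c2c1OC(C)(C)C=C2` carries a 2-methoxyphenyl, and in this assay compound 3 also stops at a limit, > 10000 nM. Compound 3 thus stands where every measured value stands: at the limit of > 10000 nM in this assay, at which 3 of the 3 values shown sit. The steps between the three, a step that the two limits leave unreadable from compound 1 to compound 2, a step that the two limits leave unreadable from compound 1 to compound 3 and a step that the two limits leave unreadable from compound 2 to compound 3, have no readable size: all three values are limits.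

Compound 4 `COc1ccc(C(=O)/C=C/c2ccc(O)c(Br)c2)c2c1C=CC(C)(C)O2` is not yet measured. The change from compound 3 is 3-bromo-4-hydroxyphenyl in place of 2-methoxyphenyl on a double-bonded chain carbon bound to a double-bonded chain carbon. Among the compounds with values here, no measured step bears on it with a readable size, so no direction beyond the scatter can be drawn from the data; the only guide is that the three aryl changes so far all left the values at the limit. Compound 4 is therefore expected to sit near that limit as well, with an estimated value of 9000 nM and a range from 2000 nM to 40000 nM. For compound 4 this estimate means a step of an at least 1.1-fold lower number from compound 3 to compound 4 (0.04 log units; that floor lies within the scatter), expected to be small, with a real chance that only a limit is reported again.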

Compound 4, half-maximal inhibitory concentration: > 10000 nM
Compound 4 was reported as a limit (the forecaster's own chance of this, stated with the estimate: 60%); middle value at least 1.1-fold (0.04 log units) away from the limit.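

Compound 4 also gives only a limit in this assay, so the steps to it from compound 1, compound 2 and compound 3 cannot be read. All four compounds stand at the same place: the limit of > 10000 nM in this assay, at which 4 of the 4 values shown sit. The compounds shown leave open whether any aryl group at this place on the shared core gives a measurable value in this assay.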